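A few compounds are considered here, and "the series" means these few. Any claim that something is new, unique, unknown or untested is made for them only; others in the source may bear on it.

Measured so far:
compound 1 `O=C(c1ccc(-c2nc(Cc3cccs3)no2)s1)C(F)(F)F`, 170 nM
compound 2 `O=C(c1ccc(-c2nc(-c3cccs3)no2)s1)C(F)(F)F`, 670 nM

Both were tested in an assay on isolated protein for inhibition of protein deacetylase HDAC6 (Homo sapiens); a lower number here means a stronger inhibitor, a higher number a weaker inhibitor. For the measured compounds named here, compound 1 gives the lower of the two numbers; the only measured step, a 3.9-fold higher number from compound 1 to compound 2 (0.60 log units; beyond the scatter), swaps the (thiophen-2-yl)methyl of compound 1 for a thiophen-2-yl bound directly to the aromatic carbon. Compound 3 `O=C(c1ccc(-c2nc(CS(=O)(=O)c3cccs3)no2)s1)C(F)(F)F` has not been measured. It differs from compound 1 by (thiophen-2-yl)sulfonyl in place of thiophen-2-yl on a saturated chain carbon bound to an aromatic carbon. Going by the values given here, the step from compound 1 to compound 2 shows that changes in this part of the molecule can move the number, but no measured step introduces a sulfonyl, so neither its direction nor its size can be read from the data. A modest weakening is expected, a 2.4-fold higher number from compound 1 to compound 3 (0.37 log units; beyond the scatter), with wide uncertainty. Compound 3 is estimated at 400 nM in this assay, between 100 nM and 1600 nM.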

Compound 3, half-maximal inhibitory concentration: 520 nM
For compound 3 the middle estimate is 1.3-fold (0.11 log units) below the measured one; low and high end bracket the measured number.
By their numbers in this assay, from the lowest: compound 1; then compounds 3 and 2 (each within the scatter of the next).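

With the thiophene ring and the saturated chain carbon both kept, adding the sulfonyl gives a 3.1-fold higher number from compound 1 to compound 3 (0.49 log units; beyond the scatter) in this assay, so this group, with more heavy atoms and hydrogen-bond acceptors than the thiophen-2-yl it replaces, does not improve on compound 1. Removing the chain carbon had already raised the number, and this second, different change to the same part of the molecule also gives a weaker inhibitor, leaving compound 1 the lowest of the three. Nothing given here explains this rise.

The compounds shown leave open whether the rise comes from the sulfonyl itself or from the larger group as a whole. A sulfonyl carrying a methyl instead of the thiophene ring, or a longer chain without a sulfonyl, could help separate the two.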